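Trifluoromethyl for Fluoro: Expected Effect on Cell Inhibition

The source may report more compounds than this note shows. Statements on the series, on what has been measured and on what is new or still open speak of the compounds shown alone.

Of the compounds shown here, three sharing one core have been measured in a functional assay on HCT-15 cells (Homo sapiens) for inhibition; on this read-out lower numbers stand for stronger inhibition and higher numbers for weaker inhibition. Compound 1 `Oc1cccc(-c2cc(-c3ccccc3F)cc(-c3ccccc3O)n2)c1` gives 8470 nM, compound 2 `Oc1cccc(-c2cc(-c3ccccc3F)cc(-c3cccc(O)c3)n2)c1` gives 5300 nM, and compound 3 `Oc1ccc(-c2cc(-c3ccccc3F)cc(-c3cccc(O)c3)n2)cc1` gives 5630 nM. Compound 2 holds the lowest of the three numbers, yet both others lie within the scatter: a 1.6-fold lower number from compound 1 to compound 2 (0.20 log units; within the scatter) and a 1.1-fold higher number from compound 2 to compound 3 (0.03 log units; within the scatter), as does a 1.5-fold lower number from compound 1 to compound 3 (0.18 log units; within the scatter). Compound 4 `Oc1cccc(-c2cc(-c3ccccc3C(F)(F)F)cc(-c3cccc(O)c3)n2)c1` differs from compound 2 by trifluoromethyl in place of fluoro on an aromatic carbon. For the measured compounds named here, none of the measured steps touches this part of the molecule; all of them exchange one hydroxyphenyl group for another and all stay within the scatter, so they give no direction for this change. For compound 4 the expected step in this assay is no change at the digits printed from compound 2 to compound 4 (within the scatter), nothing beyond the scatter. Compound 4 is estimated at 5300 nM, with a range from 1800 nM to 16000 nM.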

Compound 4, half-maximal inhibitory concentration: 8150 nM
For compound 4 the middle estimate is 1.5-fold (0.19 log units) below the measured one; the range from low to high includes it.
By their numbers in this assay, from the lowest: compounds 2, 3, 4 and 1 (each within the scatter of the next).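

For the compounds shown here, this is the first change on the fluorinated ring rather than on the hydroxyphenyl groups. In this assay, going from 2-fluorophenyl to 2-(trifluoromethyl)phenyl gives a 1.5-fold higher number from compound 2 to compound 4 (0.19 log units; within the scatter), so at this position the larger trifluoromethyl group leaves the number indistinguishable from that of fluoro. No other measurement here bears on why this exchange behaves as it does. Still open, as far as these compounds go, is whether an amine, a carboxylic acid or a longer chain on this same aromatic carbon would move the number beyond the scatter.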